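Removing a Nitro Group From a Benzyl Ether

The compounds below may be only part of what the source reports. "The series", "measured", "known", "first", "only" and "open" are said of these compounds alone.

Measured compounds:
compound 1 `O=[N+]([O-])c1cccc(COCNc2n[n+]([O-])c3ccccc3[n+]2[O-])c1`: 3440 nM
compound 2 `COc1ccc2c(c1)[n+]([O-])nc(NCOCc1ccccc1)[n+]2[O-]`: 4470 nM

Both were tested in a functional assay on A549 cells (Homo sapiens) for cytotoxicity, read by MTT assay, with a stated time of 72 h; a higher number here means a weaker inhibitor, a lower number a stronger inhibitor. Compound 1 gives 3440 nM, the lower of the two numbers, and compound 2 gives 4470 nM, which lies within the scatter of compound 1, so neither can be called stronger. Compound 3 `[O-][n+]1nc(NCOCc2ccccc2)[n+]([O-])c2ccccc21` awaits measurement. It differs from compound 1 in one place: hydrogen in place of nitro on an aromatic carbon. Within the data shown here, no measured pair shows this change directly. Compound 2 also carries no nitro and gives 4470 nM, so little movement is expected. The expected step is a 1.3-fold higher number from compound 1 to compound 3 (0.12 log units; within the scatter), within the scatter. Compound 3 is estimated at 4500 nM, between 2000 nM and 10000 nM.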

Compound 3, half-maximal inhibitory concentration: 4140 nM
Compound 3: middle estimate off by 1.1-fold (0.04 log units), on the high side; low and high end bracket the measured number.
By their numbers in this assay, from the lowest: compounds 1, 3 and 2 (each within the scatter of the next).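

In this assay, hydrogen in place of nitro on this aromatic carbon gives a 1.2-fold higher number from compound 1 to compound 3 (0.08 log units; within the scatter) and so leaves the number unchanged as far as this assay can tell. Hydrogen in place of methoxy gives a 1.1-fold lower number from compound 2 to compound 3 (0.03 log units; within the scatter) and is equally unresolved, so neither group leaves a mark that stands out from the scatter. No evidence at hand explains these small steps. Among these compounds, whether an amine or a carboxylic acid on this aromatic carbon would shift the number stays open, since nitro and hydrogen are the only groups compared there.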